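Thiazole acetic acids: aryl swap at the ring carbon

A few compounds are considered here, and "the series" means these few. Any claim that something is new, unique, unknown or untested is made for them only; others in the source may bear on it.

Measured so far:
compound 1 `O=C(O)Cc1sc(C(c2ccccc2)c2ccc(Cl)cc2)nc1-c1ccc(Cl)cc1` — 80%
compound 2 `O=C(O)Cc1sc(C(c2ccc(F)cc2)c2ccc(F)cc2)nc1-c1ccnc(Cl)c1` — 80%

In an in vitro functional assay on HEK285-7 cells for antagonist activity at prostaglandin D2 receptor 2 (Homo sapiens), read by BRET and beta-arrestin recruitment (on this read-out higher numbers stand for larger maximal responses and lower numbers for smaller maximal responses), compound 1 gives 80%. In this assay compound 2 gives 80%. Compound 2 thus stands level with compound 1 at the digits shown; the two values lie within the scatter of each other, and no order between them can be read from these numbers. Among the compounds with values here, the two compounds differ in more than one place, so no single step between them is counted.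

Compound 3 `O=C(O)Cc1sc(C(c2ccc(F)cc2)c2ccc(F)cc2)nc1-c1ccccc1` is the next member awaiting measurement in this assay. It derives from compound 2 by one change: phenyl in place of 2-chloropyridin-4-yl on an aromatic carbon.

Both measured compounds reach the same level of maximal response in this assay while carrying different aryl groups at this ring carbon, which gives no sign that the group at this place moves the maximal response. The expectation for compound 3 is therefore a step from compound 2 of a number 2 percentage points lower from compound 2 to compound 3 (within the scatter), not beyond the scatter. Compound 3 is estimated to give 78% in this assay, within a range of 60% to 95%.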

Compound 3, largest response reached (reported as efficacy), in percent of the reference or control that the assay uses: 80%
For compound 3 the middle estimate is 2 percentage points below the measured one; the range from low to high includes it.
By their numbers in this assay, from the lowest: compounds 1, 2 and 3 (each within the scatter of the next).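

In this assay, phenyl in place of 2-chloropyridin-4-yl on the aromatic carbon next to the ring nitrogen gives no change at the digits printed from compound 2 to compound 3 (within the scatter). Within the data shown here, this is the first comparison in which this group alone differs, so the level shared by the earlier pair can now be tested at this place without a second difference alongside it: losing the ring nitrogen, the chlorine and the counted hydrogen-bond acceptor of the leaving group does not separate the maximal responses of this pair, at least for this one exchange of six-membered aromatic rings. No measurement at hand accounts for this outcome.

From the compounds shown here alone, whether a group without an aromatic ring at this carbon, such as cyclohexyl or an amine such as morpholine, would keep the maximal response at this level remains open. All the compounds shown also carry the carboxymethyl group on the neighbouring ring atom, so it is equally open how this result would hold with a longer chain there, such as carboxyethyl.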